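The compounds below may be only part of what the source reports. "The series", "measured", "known", "first", "only" and "open" are said of these compounds alone.

Compound 3 `CCOC(=O)c1cnc(-c2ccc(C(F)(F)F)cc2)nc1NN1C(=O)C=C(C)C1=O` stands lowest of the three numbers measured in a functional assay on Jurkat cells for inhibition of nuclear factor NF-kappa-B complex (Homo sapiens); on this read-out higher numbers stand for weaker inhibition and lower numbers for stronger inhibition: compound 3 gives 400 nM, whereas compound 1 `CCOC(=O)c1cnc(CC)nc1NN1C(=O)C=C(C)C1=O` gives 10000 nM and compound 2 `CCOC(=O)c1cnc(-c2cnc3ccccc3c2)nc1NN1C(=O)C=C(C)C1=O` gives 6000 nM. Compound 4 `CCOC(=O)c1cnc(-c2cc3ccccc3s2)nc1NN1C(=O)C=C(C)C1=O` differs from compound 3 in one place: 1-benzothiophen-2-yl in place of 4-(trifluoromethyl)phenyl on an aromatic carbon. Going by the values given here, two measured steps bear on this change. Quinolin-3-yl in place of ethyl on the same aromatic carbon gave a 1.7-fold lower number from compound 1 to compound 2 (0.22 log units; within the scatter), while 4-(trifluoromethyl)phenyl gave a 25-fold lower number from compound 1 to compound 3 (1.40 log units; beyond the scatter) and a 15-fold lower number from compound 2 to compound 3 (1.18 log units; beyond the scatter). Among the compounds with values here, the only other ring-fused group, in compound 2, stayed close to compound 1, so the number for compound 4 is expected to rise, by a 3.8-fold higher number from compound 3 to compound 4 (0.57 log units; beyond the scatter) in this assay. Compound 4 is thus estimated at 1500 nM, with a range of 400 nM to 6000 nM.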

Compound 4, half-maximal inhibitory concentration: 4000 nM
Compound 4: middle estimate off by 2.7-fold (0.43 log units), on the low side; the range from low to high includes it.
By their numbers in this assay, from the lowest: compound 3; then compounds 4, 2 and 1 (each within the scatter of the next, the first and the last beyond it).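

In this assay, 1-benzothiophen-2-yl, a second ring-fused group at this carbon, gives up most of the gain seen with 4-(trifluoromethyl)phenyl (a 10-fold higher number from compound 3 to compound 4 (1.00 log units; beyond the scatter)). It cannot be told apart from quinolin-3-yl (a 1.5-fold lower number from compound 2 to compound 4 (0.18 log units; within the scatter)), yet unlike quinolin-3-yl it does separate from ethyl (a 2.5-fold lower number from compound 1 to compound 4 (0.40 log units; beyond the scatter)). No measurement at hand explains these differences. Open, from the compounds shown here alone, is whether unsubstituted phenyl, 4-chlorophenyl or an amine at this carbon would stay near compound 3, and whether a carboxylic acid could stand in place of the ethoxycarbonyl group.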